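Working notes: from compound 3 to compound 4

The source may hold more compounds than are shown below. What is called first, only, known or untested is meant among the compounds shown, and "the series" means these compounds.

Measured so far:
- compound 1 `N#C/C(=C\c1ccccc1OS(=O)(=O)c1ccc(F)cc1)C(=O)Nc1nnc(Cc2cccc3ccccc23)s1`: 12%
- compound 2 `N#C/C(=C\c1ccccc1OS(=O)(=O)c1ccc(F)cc1)C(=O)Nc1nnc(Cc2ccccc2)s1`: 22%
- compound 3 `Cc1ccc(S(=O)(=O)Oc2ccccc2/C=C(\C#N)C(=O)Nc2nnc(Cc3cccc(F)c3)s2)cc1`: 11%

In a functional assay on HL-60 cells (Homo sapiens) for inhibition, read by CCK-8 assay, with a stated time of 48 h, tested at 20 uM (a higher number here means more inhibition of growth at the concentration tested, a lower number less inhibition of growth), compound 3 gives 11%. That number is level, within the scatter, with compound 1 at 12%, while the gap to compound 2 at 22% lies beyond the scatter.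

Compound 4 `N#C/C(=C\c1ccccc1OS(=O)(=O)c1ccc(F)cc1)C(=O)Nc1nnc(Cc2cccc(F)c2)s1` differs from compound 3 at one place: fluoro in place of methyl on an aromatic carbon. This is fluoro in place of methyl on an aromatic carbon, para to a large group, so 4-methylphenyl becomes 4-fluorophenyl.

For the measured compounds named here, no measured step covers this change. Going by the values given here, the only measured step, a number 10 percentage points higher from compound 1 to compound 2 (within the scatter), is phenyl in place of naphthalen-1-yl on a saturated chain carbon, a change elsewhere in the molecule, and it gives no sign of a large effect. Compound 2, which carries the entering 4-fluorophenyl group, gives 22%, so no large rise is expected.

The expected change in this assay stays within the scatter, with only a weak lean upward: a number 4 percentage points higher from compound 3 to compound 4 (within the scatter). For compound 4 the estimate is 15%, with an expected range of 5% to 27%.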

Compound 4, percent growth inhibition at one concentration: 22%
For compound 4 the middle estimate is 7 percentage points below the measured one, and the stated range covers the measured number.
By their numbers in this assay, from the lowest: compounds 3, 1, 2 and 4 (each within the scatter of the next, the first and the last beyond it).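

In this assay, for the compounds shown here, fluoro in place of methyl on an aromatic carbon, para to a large group, gives the first reading at this position: a number 11 percentage points higher from compound 3 to compound 4 (beyond the scatter), so 4-fluorophenyl and 4-methylphenyl on the sulfonyl are separated by a modest step. At the other end of the molecule, fluoro in place of hydrogen gives no change at the digits printed from compound 2 to compound 4 (within the scatter), and 3-fluorophenyl in place of naphthalen-1-yl on the saturated chain carbon gives a number 10 percentage points higher from compound 1 to compound 4 (within the scatter), so neither of these two changes moves the number beyond the scatter, and among the steps to compound 4 only the change on the sulfonyl side does. Nothing at hand accounts for the step from methyl to fluoro.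

On these data alone, the step from methyl to fluoro is read on a single background, the one with 3-fluorophenyl, so whether it carries over to phenyl or naphthalen-1-yl on the saturated chain carbon stays open. As far as these compounds go, how a methoxy group, an amine or a carboxylic acid in place of that fluoro would read in this assay also stays open.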